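From methyl to chloro in a cytotoxic series

A few compounds are considered here, and "the series" means these few. Any claim that something is new, unique, unknown or untested is made for them only; others in the source may bear on it.

- compound 1 `COc1ccc2c(c1)CCCN2c1nc(C)nc2ccccc12`: 1.5 nM
- compound 2 `COc1cccc2cc(N(C)c3nc(C)nc4ccccc34)ccc12`: 2.9 nM
- compound 3 `CSc1ccc(N(C)c2ncnc3ccccc23)cc1`: 13.6 nM

Within the data shown here, these three compounds were tested in a functional assay on SK-OV-3 cells (Homo sapiens) for cytotoxicity, read by sulforhodamine B assay (on this read-out higher numbers stand for weaker inhibition and lower numbers for stronger inhibition), and together they give a first view of the numbers to expect. Here compound 2 gives 2.9 nM as its result. That sits within the usual scatter of compound 1 at 1.5 nM and so the two cannot be told apart. By contrast, compound 3 at 13.6 nM stands beyond the scatter from compound 2, on the side of weaker inhibition.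

The compound still to be measured is compound 4 `COc1cccc2cc(N(C)c3nc(Cl)nc4ccccc34)ccc12` and it keeps the rest of compound 2 unchanged. Among the measured compounds shown here, the single change is chloro in place of methyl on an aromatic carbon and it means chloro in place of methyl on an aromatic carbon, between two ring nitrogen atoms. For the measured compounds named here, no measured pair shows this exchange directly, so any forecast is uncertain. The closest guide is compound 2 itself at 2.9 nM as the starting point, and only a small shift from it seems likely. The expected change is a 1.7-fold higher number from compound 2 to compound 4 (0.24 log units; within the scatter) and this estimated step may well stay within the scatter. For compound 4 the estimated value is 5 nM with an expected range from 1.5 nM to 20 nM as the likely span.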

Compound 4, half-maximal inhibitory concentration: 2.8 nM
The estimate for compound 4 lay 1.8-fold (0.25 log units) above the measured number; the range from low to high includes it.
By their numbers in this assay, from the lowest: compounds 1, 4 and 2 (each within the scatter of the next); then compound 3.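

Among these compounds, the earlier compounds offered no pair differing in one place, so this is the first direct look at what a change on the shared core does. In this assay, chloro in place of methyl on an aromatic carbon, between two ring nitrogen atoms, gives a 1.0-fold lower number from compound 2 to compound 4 (0.02 log units; within the scatter) and so the two compounds cannot be told apart, which shows that at this position, on this core, either group gives the same reading within the usual scatter. Nothing measured here explains why the two groups read alike, and one pair cannot show whether any property of the groups is involved.

On these data alone, what an amine, a nitrile or a longer chain such as propyl would do on this same carbon stays open, so it is unknown whether this position accepts very different groups or only these two small ones. Also open, as far as these compounds go, is whether the exchange of methyl for chloro would read the same way on the core of compound 1, or in cells other than those of this one assay.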